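This account rests on a few compounds, and the source may have more. Where it says the series, first, only, none or still open, it means among the compounds named here.

Measured in a functional assay on B16-F10 cells (Mus musculus); on this read-out lower numbers stand for an effect already at smaller amounts and higher numbers for an effect only at larger amounts of compound:

- Compound 1 `Nc1ncn(C[C@@H]2CO[C@H](CO)O2)c(=O)n1`: 70000 nM
- Compound 2 `Cc1nn(C[C@@H]2CO[C@H](CO)O2)c(=O)[nH]c1=O`: > 100000 nM (a limit of the assay, not a number)

Going by the values given here, compound 1 holds the only true number in this small set. In this assay compound 1 gives 70000 nM, so it acts only at large amounts. Among the compounds with values here, the one other reading, for compound 2, is a limit, and the two compounds are not linked by a single change.

The next compound is compound 3 `Nc1ncn(C[C@H]2CO[C@@H](CO)O2)c(=O)n1`. Its relation to compound 1 is the two compounds have the same atoms and bonds and differ only in configuration as drawn: 2 of 2 stereo elements differ (all stereocentres are inverted: mirror images); a stereocentre at a saturated ring carbon is drawn R in compound 1 and S in compound 3; a stereocentre at a saturated ring carbon is drawn S in compound 1 and R in compound 3. All stereocentres are inverted, so the two are mirror images, with the same atoms and bonds.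

Within the data shown here, no measured pair shows what such an inversion does on this read-out, so the expectation stays cautious. With nothing to favour a large shift, only a small move towards larger amounts is expected, not clearly beyond the usual scatter. The expected 1.3-fold higher number from compound 1 to compound 3 (0.11 log units; within the scatter) is of that modest size. A reading that reaches the limit of the assay would not be surprising.

Compound 3 is estimated at 90000 nM, with an expected range of 30000 nM to 200000 nM.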

Compound 3, half-maximal effective concentration: 60000 nM
Estimate against measurement, compound 3: 1.5-fold (0.18 log units) above, and the stated range covers the measured number.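

In this assay, inverting both stereocentres at the saturated ring carbons gives a 1.2-fold lower number from compound 1 to compound 3 (0.07 log units; within the scatter), so the two mirror images cannot be told apart on this read-out. Going by these compounds alone, this is the first pair in the set that can be read as a single comparison, and the reading is a clean one, with no other structural feature to account for: the fact that compounds 1 and 3 differ only in the configuration as drawn At this level of effect, where both compounds act only at large amounts, the configuration as drawn at these two ring carbons shows no influence beyond the usual scatter, which the earlier compounds could not show.

For compound 2 the reading remains a limit of the assay, > 100000 nM, and it is tied to neither of the other compounds by a single change. Still open, as far as these compounds go, is what inverting only one of the two stereocentres would do, and whether a group such as a carboxylic acid or a longer chain on the shared core would move the number in this assay at all.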